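Replacing 3-fluorophenyl with 4-methylpiperidin-1-yl on the shared core

This account rests on a few compounds, and the source may have more. Where it says the series, first, only, none or still open, it means among the compounds named here.

In an ADME assay (liver) for metabolic stability, with Liver microsome (Rattus norvegicus) as the target, using microsomes (a higher number here means faster removal of the compound, a lower number slower removal), compound 1 (`O=C(O)c1csc(-n2nc(-c3ccccc3)c3cc(F)ccc32)n1`) gives 345 mL/min/kg and compound 2 (`O=C(O)c1csc(-n2nc(-c3ccccc3)c3ccc(F)cc32)n1`) gives 337 mL/min/kg. Compound 3 (`O=C(O)c1csc(-n2nc(-c3cccc(F)c3)c3ccccc32)n1`) gives 385 mL/min/kg, which lies within the scatter of both other values, so the three cannot be ranked. Compound 4 (`CC1CCN(c2nn(-c3nc(C(=O)O)cs3)c3ccccc23)CC1`) has not yet been measured. It carries 4-methylpiperidin-1-yl in place of 3-fluorophenyl on an aromatic carbon. Within the data shown here, no measured pair shows a change at this place, so the expectation rests on the three values alone: a small step towards slower removal in this assay, probably not beyond the scatter. The estimated step runs a 1.3-fold lower number from compound 3 to compound 4 (0.12 log units; within the scatter). For compound 4 the expected clearance is 290 mL/min/kg, with an estimated range of 140 mL/min/kg to 520 mL/min/kg.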

Compound 4, clearance: 260 mL/min/kg
Estimate against measurement, compound 4: 1.1-fold (0.05 log units) above; measured number inside the range.
By their numbers in this assay, from the lowest: compounds 4, 2, 1 and 3 (each within the scatter of the next).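

At this position, on an aromatic carbon next to the ring nitrogen, 4-methylpiperidin-1-yl in place of 3-fluorophenyl gives a 1.5-fold lower number from compound 3 to compound 4 (0.17 log units; within the scatter) in this assay. Exchanging a six-membered aromatic ring of carbon only for a six-membered non-aromatic ring with a hetero atom therefore does not separate the two compounds in this read-out. On these data alone, whether another amine here, such as morpholin-4-yl or dimethylamino, would give a step beyond the scatter remains open. Nothing measured here offers an explanation for this step.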